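A few compounds are considered here, and "the series" means these few. Any claim that something is new, unique, unknown or untested is made for them only; others in the source may bear on it.

Measured compounds in a physicochemical assay for solubility, in phosphate buffer, measured as kinetic solubility, with a stated time of 1 h, at pH 7.4; on this read-out higher numbers stand for higher solubility and lower numbers for lower solubility:
- compound 1, `COc1ccc2nc(C)cc(OCC(=O)Nc3cccc(C)c3)c2c1`, gives 193000 nM
- compound 2, `COc1cccc(NC(=O)COc2cc(C)nc3ccc(OC)cc23)c1`, gives 35000 nM
- compound 3, `COc1ccc2nc(C)cc(OCC(=O)Nc3cc(C)ccc3OC)c2c1`, gives 9500 nM

Compound 3 has the lowest number of the three: the step of a 3.7-fold lower number from compound 2 to compound 3 (0.57 log units; beyond the scatter) and the step of a 20-fold lower number from compound 1 to compound 3 (1.31 log units; beyond the scatter) both lie beyond the scatter. The next compound, compound 4, `COc1ccc2nc(C)cc(OCC(=O)Nc3ccc(Cl)cc3Cl)c2c1`, has not yet been measured in this assay. It differs from compound 3 in one place: 2,4-dichlorophenyl in place of 2-methoxy-5-methylphenyl on an amide-type nitrogen. Among the compounds with values here, no measured step swaps one aryl group on that nitrogen for one carrying chlorine, so the closest guide is the step of a 3.7-fold lower number from compound 2 to compound 3 (0.57 log units; beyond the scatter), a modest change from one such aryl group to another. A step of similar size, downward or none beyond the scatter, is expected in this assay, namely a 1.9-fold lower number from compound 3 to compound 4 (0.28 log units; within the scatter). Compound 4 is therefore estimated at 5000 nM, within 1500 nM to 18000 nM.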

Compound 4, solubility: 20500 nM
Compound 4: middle estimate off by 4.1-fold (0.61 log units), on the low side; measured number outside the range, above it.
By their numbers in this assay, from the lowest: compound 3; then compounds 4 and 2 (each within the scatter of the next); then compound 1.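

In this assay, swapping the aryl group on the amide-type nitrogen can also raise the number: with 2,4-dichlorophenyl there is a 2.2-fold higher number from compound 3 to compound 4 (0.33 log units; beyond the scatter), the only upward step among those shown. The same group cannot be told apart from 3-methoxyphenyl, with a 1.7-fold lower number from compound 2 to compound 4 (0.23 log units; within the scatter), but it falls well short of 3-methylphenyl, with a 9.4-fold lower number from compound 1 to compound 4 (0.97 log units; beyond the scatter). Nothing measured here explains these steps. Open, from the compounds shown here alone, is how an aryl group carrying a carboxylic acid or an amine would read on this nitrogen, and whether a single chlorine would match 2,4-dichlorophenyl.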